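The source may hold more compounds than are shown below. What is called first, only, known or untested is meant among the compounds shown, and "the series" means these compounds.

Going by the values given here, compound 1 `FC(F)(F)c1ccc(-c2ccc3c(NCCCNCc4ccco4)ccnc3c2)cc1` is one of three compounds measured in an ADME assay for permeability, using PAMPA, with a stated time of 30 min, at pH 7.4 (on this read-out lower numbers stand for lower permeability and higher numbers for higher permeability), where compound 1 gives 237 10^-6 cm/s. That number is the second highest of the three: compound 2 `COc1cccc(Oc2ccc3c(NCCCNCc4cccc(OC)c4O)ccnc3c2)c1` gives 317 10^-6 cm/s, which lies within the usual scatter of the number for compound 1, while compound 3 `CCC(CC)c1ccc2c(NCCCNCc3cc(F)ccc3OC)ccnc2c1` gives 23 10^-6 cm/s, a gap well beyond the scatter. Compound 4 `Fc1ccc(Cc2ccc3c(NCCCNCc4ccco4)ccnc3c2)c(Cl)c1` has not yet been measured. It differs from compound 1 in one place: 2-chloro-4-fluorobenzyl in place of 4-(trifluoromethyl)phenyl on an aromatic carbon. Among the compounds with values here, no measured pair shows this same change, so the expectation for the step from compound 1 to compound 4 rests on the number for compound 1 alone, and no shift beyond the scatter is expected, namely a 1.2-fold lower number from compound 1 to compound 4 (0.07 log units; within the scatter). Compound 4 is therefore expected to give about 200 10^-6 cm/s, most likely between 80 10^-6 cm/s and 420 10^-6 cm/s.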

Compound 4, apparent permeability: 23 10^-6 cm/s
Compound 4: the middle estimate sits 8.7-fold (0.94 log units) above what was measured; the whole stated range lies above it.
By their numbers in this assay, from the lowest: compounds 3 and 4 (each within the scatter of the next); then compounds 1 and 2 (each within the scatter of the next).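

Placing 2-chloro-4-fluorobenzyl in place of 4-(trifluoromethyl)phenyl gives a 10-fold lower number from compound 1 to compound 4 (1.01 log units; beyond the scatter) in this assay and shows that this position on the shared core can strongly move the number. The two groups look alike by simple counts: each has one six-membered aromatic ring of carbon only and no hydrogen-bond donors or acceptors. Nothing available explains the drop. This single step changes the connection to the ring and the halogens together, leaving open which of them matters. An unsubstituted benzyl group or a 4-(trifluoromethyl)benzyl group at this position would help separate them.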